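Thioether side-chain variation on a shared core

The compounds below may be only part of what the source reports. "The series", "measured", "known", "first", "only" and "open" are said of these compounds alone.

Measured in a functional assay on HT cells (Homo sapiens) for antiproliferative activity, read by fluorescence, with a stated time of 72 h; a lower number here means a stronger inhibitor of growth, a higher number a weaker inhibitor of growth:
compound 1 `CC(C)c1n[nH]c2c(NCc3ccc(-c4ccccn4)cc3)nc(SCC(O)C(F)(F)F)nc12` gives 690 nM
compound 2 `CC(C)c1n[nH]c2c(NCc3ccc(-c4ccccn4)cc3)nc(SCCNC(=N)N)nc12` gives 390 nM

Compound 2 holds the lowest of the two numbers, with compound 1 nearest: a 1.8-fold lower number from compound 1 to compound 2 (0.25 log units; within the scatter). Compound 3 `C=CCSc1nc(NCc2ccc(-c3ccccn3)cc2)c2[nH]nc(C(C)C)c2n1` is the next change at the same place: a group of 2 heavy atoms (2 carbon; no ring) in place of a group of 5 heavy atoms (2 carbon, 3 nitrogen; no ring), on a saturated chain carbon bound to a sulfur. Among the measured compounds shown here, the only step that bears on it is the one from compound 1 to compound 2, which stayed within the scatter, so no step beyond the scatter is expected in this assay for compound 3. Compound 3 is therefore estimated at 600 nM, range 250 nM to 1500 nM, an expected step of a 1.5-fold higher number from compound 2 to compound 3 (0.19 log units; within the scatter).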

Compound 3, concentration for 50% growth inhibition: 1010 nM
Compound 3: the middle estimate sits 1.7-fold (0.23 log units) below what was measured; the measured number falls inside the stated range.
By their numbers in this assay, from the lowest: compounds 2, 1 and 3 (each within the scatter of the next, the first and the last beyond it).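

In this assay, this position now shows its first step beyond the scatter (a 2.6-fold higher number from compound 2 to compound 3 (0.41 log units; beyond the scatter)), with vinyl entering on the saturated chain carbon bound to a sulfur. Vinyl and 2,2,2-trifluoro-1-hydroxyethyl remain within the scatter of each other (a 1.5-fold higher number from compound 1 to compound 3 (0.17 log units; within the scatter)), so compound 1 is not separated from either neighbour and only the pair compound 2 and compound 3 is resolved. No evidence on hand accounts for this step.

An amine, a carboxylic acid or a longer chain at this place would show whether the separation extends beyond these three groups. The shown compounds also leave open how far the step depends on the shared core.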